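Aryl methyl step in a cytotoxicity series

A few compounds are considered here, and "the series" means these few. Any claim that something is new, unique, unknown or untested is made for them only; others in the source may bear on it.

Measured compounds:
compound 1 `CCOC(=O)c1c(-c2cc3ccccc3oc2=O)nn(-c2cccc(C)c2)c1C(=O)OCC` 52000 nM
compound 2 `CCOC(=O)c1c(-c2cc3ccccc3oc2=O)nn(-c2ccc(C)c(C)c2)c1C(=O)OCC` 52000 nM
compound 3 `CCOC(=O)c1c(-c2cc3cc(OC)ccc3oc2=O)nn(-c2ccccc2)c1C(=O)OCC` 35000 nM

All three were read in a functional assay on A549 cells (Homo sapiens) for cytotoxicity, read by MTT assay, with a stated time of 48 h; a lower number here means a stronger inhibitor, a higher number a weaker inhibitor. Compound 1 and compound 2 share one core and differ by methyl in place of hydrogen on an aromatic carbon. That step, no change at the digits printed from compound 1 to compound 2 (within the scatter), is flat. Compound 3 carries a different core; the difference between the two cores is not broken down here. In this assay compound 3 gives 35000 nM, and its gap to compound 1 and to compound 2 is within the scatter, so no order among the three is claimed.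

Compound 4 `CCOC(=O)c1c(-c2cc3cc(OC)ccc3oc2=O)nn(-c2cccc(C)c2)c1C(=O)OCC` is not yet measured. It differs from compound 3 by methyl in place of hydrogen on an aromatic carbon. This is the same kind of change as methyl in place of hydrogen on an aromatic carbon, though the surroundings differ: in compound 4 the methyl enters meta to a large group, whereas in compound 2 it enters ortho to a methyl group and para to a large group. Compound 4 is expected to show a step of a 1.1-fold higher number from compound 3 to compound 4 (0.04 log units; within the scatter), resting on the flat step no change at the digits printed from compound 1 to compound 2 (within the scatter). Compound 4 is therefore estimated at 38000 nM, between 17000 nM and 85000 nM.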

Compound 4, half-maximal inhibitory concentration: 102000 nM
Compound 4: middle estimate off by 2.7-fold (0.43 log units), on the low side; measured number above the stated range.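

In this assay, phenyl to 3-methylphenyl on the methoxy-bearing core gives a 2.9-fold higher number from compound 3 to compound 4 (0.46 log units; beyond the scatter), a modest step. Set beside the earlier methyl step, the same change does not carry over unchanged from one core to the other: the same change on two cores in this assay, no change at the digits printed (within the scatter) from compound 1 to compound 2 and a 2.9-fold higher number (0.46 log units; beyond the scatter) from compound 3 to compound 4, 2.9-fold (0.46 log units) apart, beyond the scatter of two such steps

A flat methyl step on one core is therefore no safe guide to the other, but the data do not show why the two steps differ, whether through the methoxy or through the different surroundings of the methyl on the aryl ring, and the methoxy step itself, a 2.0-fold higher number from compound 1 to compound 4 (0.29 log units; within the scatter), gives no ground for claiming an effect of methoxy alone.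

The compounds shown leave open whether any such difference between the cores extends to groups other than methyl on the aryl ring, such as an amine or a chlorine atom. On these data alone, the two ethyl esters stay the same throughout, so the outcome with a carboxylic acid or an amide in their place also remains open.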